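Notes on a 2-carboxyphenyl replacement for 1,2-thiazol-4-yl

The source may hold more compounds than are shown below. What is called first, only, known or untested is meant among the compounds shown, and "the series" means these compounds.

Measured so far:
- compound 1, `c1ccc(-c2ccc(CCc3nc(CC4CCCC4)c[nH]3)cc2)nc1`: 103 nM
- compound 2, `CCC(C)(C)Cc1c[nH]c(CCc2ccc(-c3cnsc3)cc2)n1`: 119 nM

Among the measured compounds shown here, in a functional assay on HEK293 cells for agonist activity at Bombesin receptor subtype-3 (Mus musculus), read by luminescence and calcium flux, with a stated time of 10 min (on this read-out lower numbers stand for an effect already at smaller amounts and higher numbers for an effect only at larger amounts of compound), compound 2 gives 119 nM, the higher of the two numbers so far; the nearest is compound 1 at 103 nM, and the gap between them lies within the scatter, so the two compounds cannot be separated on these data.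

The next compound, compound 3 `CCC(C)(C)Cc1c[nH]c(CCc2ccc(-c3ccccc3C(=O)O)cc2)n1`, keeps the rest of compound 2 unchanged and differs in one place: 2-carboxyphenyl in place of 1,2-thiazol-4-yl on an aromatic carbon. The group that leaves is a five-membered aromatic ring with two hetero atoms; the group that enters is a six-membered aromatic ring of carbon only carrying one hydrogen-bond donor and one hydrogen-bond acceptor, and it is the larger of the two in heavy atoms.

For the measured compounds named here, no measured pair shows a step of this kind, so the direction is not fixed by the data. The expected outcome for compound 3 is a modest move toward a higher number, a step of a 2.1-fold higher number from compound 2 to compound 3 (0.32 log units; beyond the scatter) that is estimated to fall at the edge of the scatter, because compound 2 gives 119 nM and offers the only anchor. Compound 3 is expected at 250 nM in this assay, within a range of 60 nM to 1500 nM.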

Compound 3, half-maximal effective concentration: 94 nM
Compound 3: the middle estimate sits 2.7-fold (0.42 log units) above what was measured; the range from low to high includes it.
By their numbers in this assay, from the lowest: compounds 3, 1 and 2 (each within the scatter of the next).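

In this assay, 2-carboxyphenyl in place of 1,2-thiazol-4-yl gives a 1.3-fold lower number from compound 2 to compound 3 (0.10 log units; within the scatter), the only one-place step among the compounds shown, and it leaves compound 2 and compound 3 inseparable. This position, on an aromatic carbon para to a large group, therefore accepts a six-membered aromatic ring of carbon only with 9 heavy atoms in place of a five-membered aromatic ring with 5 heavy atoms, and the exchange also brings in a hydrogen-bond donor, with no step beyond the scatter on this read-out. The data at hand offer no measurement that would account for this result.

Still open, from the compounds shown here alone, is whether a plain phenyl, a methyl ester or a primary amide at this place would read the same as 2-carboxyphenyl, which would show whether the carboxylic acid contributes to the value at all. Also open, going by these compounds, is whether the same exchange would read the same on the core of compound 1, which differs from compound 2 in more than one place and so offers no direct comparison here.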